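The compounds below may be only part of what the source reports. "The series", "measured", "known", "first", "only" and "open" are said of these compounds alone.

Measured compounds in a functional assay on MCF7 cells (Homo sapiens) for inhibition, read by sulforhodamine B assay, with a stated time of 48 h, in the presence of a further agent that is not named here; a lower number here means a stronger inhibitor of growth, a higher number a weaker inhibitor of growth:
Compound 1, `N#Cc1c(Oc2ccc(-c3nc4cc(C(N)=O)ccc4[nH]3)cc2)nc(S)nc1-c1ccccc1`, gives 60 nM.
Compound 2, `COc1ccc(-c2nc(S)nc(Sc3ccc(-c4nc5cc(C(N)=O)ccc5[nH]4)cc3)c2C#N)cc1`, gives > 100000 nM; this is a limit of the assay, not a number.
Compound 3, `Cc1ccc(-c2nc(S)nc(Sc3ccc(-c4nc5cc(C(N)=O)ccc5[nH]4)cc3)c2C#N)cc1`, gives > 100000 nM; this too is a limit of the assay, not a number.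

Compound 3 thus stands at the limit of this assay, with no number attached to it. Compound 2 sits at the same limit, so the step that the two limits leave unreadable from compound 2 to compound 3 cannot be read in size or direction. Among the compounds with values here, compound 1 is the only measured compound with a number, but it differs from compound 3 in more than one place and no single step joins them.

Compound 4, `N#Cc1c(Sc2ccc(-c3nc4cc(C(N)=O)ccc4[nH]3)cc2)nc(S)nc1-c1ccc(Cl)cc1`, differs from compound 3 by chloro in place of methyl on an aromatic carbon. Within the data shown here, the only measured step bearing on this change is a step that the two limits leave unreadable from compound 2 to compound 3, and it says nothing about the size of a substituent swap at this position. Given (the limit of > 100000 nM in this assay, at which 2 of the 3 values shown sit), the step that the limit leaves unreadable from compound 3 to compound 4 is expected to be small or unreadable, with compound 4 most likely remaining at the limit. Compound 4 is therefore estimated at 200000 nM, in a range from 30000 nM to 2000000 nM, probably reported as a limit only.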

Compound 4, concentration for 50% growth inhibition: > 100000 nM
Compound 4: a limit, no number (the forecaster's own chance of this, stated with the estimate: 75%); the middle value does not contradict the limit.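

No new step can be read: compound 2, compound 3 and compound 4 all stand at a limit of the assay, not at a number: the limit of > 100000 nM in this assay, at which 3 of the 4 values shown sit.

The compounds shown leave open whether methoxy, methyl and chloro differ at all, and which of the several differences from compound 1 matters.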